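The source may hold more compounds than are shown below. What is called first, only, known or untested is meant among the compounds shown, and "the series" means these compounds.

Measured in an assay on isolated protein for inhibition of leukotriene B4 receptor 1 (Homo sapiens), tested at 10 uM; on this read-out lower numbers stand for less inhibition and higher numbers for more inhibition at the one concentration tested (going by the name of the read-out):
compound 1 `C=CCc1cc(C(C)=O)c(O)cc1OCCCCC` gives 60%
compound 2 `C=CCCCCOc1cc(O)c(C(C)=O)cc1CC=C` gives 73%
compound 3 `C=CCc1cc(C(C)=O)c(O)cc1OCCCCO` gives 48%

Compound 3 stands lowest of the three in this assay, below compound 1 by a number 12 percentage points lower from compound 1 to compound 3 (beyond the scatter) and below compound 2 by a number 25 percentage points lower from compound 2 to compound 3 (beyond the scatter). Compound 4 `C=CCc1cc(C(C)=O)c(O)cc1OCCCCCC(=O)N(C)C` is not yet measured; it differs from compound 3 by (dimethylcarbamoyl)methyl in place of hydroxy on a saturated chain carbon, four bonds along the chain from an oxygen on an aromatic ring. The two measured steps at this chain position both bear on it: exchanging the hydroxy for a carbon-only group, methyl or vinyl, raised inhibition by modest amounts. The (dimethylcarbamoyl)methyl group likewise removes the hydrogen-bond donor, so a modest rise beyond the scatter is expected for compound 4, though the new group is larger than either comparator. Compound 4 is estimated at 60%, range 45% to 75%. The expected step is a number 12 percentage points higher from compound 3 to compound 4 (beyond the scatter).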

Compound 4, a percentage reported as inhibition, at one concentration (the size of the read-out at that concentration, not a potency): 92%
For compound 4 the middle estimate is 32 percentage points below the measured one, and the stated range ends below it.
By their numbers in this assay, from the lowest: compound 3; then compound 1; then compound 2; then compound 4.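

In this assay, (dimethylcarbamoyl)methyl on this saturated chain carbon puts compound 4 above all three earlier compounds: a number 44 percentage points higher from compound 3 to compound 4 (beyond the scatter), a number 19 percentage points higher from compound 2 to compound 4 (beyond the scatter) and a number 32 percentage points higher from compound 1 to compound 4 (beyond the scatter). The position therefore accepts a much larger group, and replacing the hydroxy is not enough on its own to reach this level, since compound 1 and compound 2 also lack that hydroxy and stay lower. No measured evidence accounts for the rise.

On these data alone, it remains open whether a carboxylic acid, a primary amide or a piperidine amide would match the dimethylamide. As far as these compounds go, the effect of a shorter or longer chain carrying that amide is also open.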